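Swapping methyl for methoxy in a cytotoxic series

A few compounds are considered here, and "the series" means these few. Any claim that something is new, unique, unknown or untested is made for them only; others in the source may bear on it.

Compound 1 `O=c1[nH]c(N/N=C/c2ccc(F)cc2)nc2nc(-c3cccs3)cc(-c3ccccc3)c12`: 1540 nM
Compound 2 `O=c1[nH]c(N/N=C/c2ccc(Cl)cc2)nc2nc(-c3cccs3)cc(-c3ccccc3)c12`: 23800 nM
Compound 3 `Cc1ccc(/C=N/Nc2nc3nc(-c4cccs4)cc(-c4ccccc4)c3c(=O)[nH]2)cc1`: 630 nM

In a functional assay on PC-3 cells (Homo sapiens) for cytotoxicity, read by sulforhodamine B assay, with a stated time of 48 h (a lower number here means a stronger inhibitor, a higher number a weaker inhibitor), compound 3 has the lowest number of the three, at 630 nM. Replacing fluoro with methyl gave a 2.4-fold lower number from compound 1 to compound 3 (0.39 log units; beyond the scatter), a modest step. Replacing chloro with methyl gave a 38-fold lower number from compound 2 to compound 3 (1.58 log units; beyond the scatter), and replacing fluoro with chloro gave a 15-fold higher number from compound 1 to compound 2 (1.19 log units; beyond the scatter), both large steps.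

Compound 4 `COc1ccc(/C=N/Nc2nc3nc(-c4cccs4)cc(-c4ccccc4)c3c(=O)[nH]2)cc1` has methoxy in place of methyl on an aromatic carbon, para to a large group: methoxy in place of methyl on an aromatic carbon. Among the measured compounds shown here, no measured step involves methoxy, so the three steps show only that changes at this place have moved the number by modest to large amounts. Compound 3 already stands at the low end with 630 nM, so a modest rise in this assay is expected, although a larger one cannot be excluded. The estimated step is a 1.9-fold higher number from compound 3 to compound 4 (0.28 log units; within the scatter). For compound 4 the expected value is 1200 nM, with an estimated range from 250 nM to 7000 nM.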

Compound 4, half-maximal inhibitory concentration: 18200 nM
Beside the measured number, compound 4's estimate is 15-fold (1.18 log units) below it; measured number outside the range, above it.
By their numbers in this assay, from the lowest: compound 3; then compound 1; then compounds 4 and 2 (each within the scatter of the next).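

In this assay, the change from 4-methylphenyl to 4-methoxyphenyl is a large one (a 29-fold higher number from compound 3 to compound 4 (1.46 log units; beyond the scatter)), so at this place on the ring, para to a large group, adding a single oxygen to the methyl group is enough to lose most of what compound 3 had. Methoxy does not separate from chloro here (a 1.3-fold lower number from compound 2 to compound 4 (0.12 log units; within the scatter)) but stands clearly apart from fluoro (a 12-fold higher number from compound 1 to compound 4 (1.07 log units; beyond the scatter)), so among these four compounds only the methyl and fluoro compounds hold the lower numbers. Nothing available explains why the methoxy compound sits with the chloro compound and not with the methyl compound.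

The compounds shown leave open whether a hydroxyl group or an ethyl group at this place would stay near compound 3 or fall near compound 4. They also leave open how an amine or a trifluoromethyl group would behave there.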